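A few compounds are considered here, and "the series" means these few. Any claim that something is new, unique, unknown or untested is made for them only; others in the source may bear on it.

Three compounds share one core: compound 1 `O=C(Nc1cccc(NC(=O)c2ccccc2Cl)c1)c1cccc(Cl)c1`, compound 2 `O=C(Nc1cccc(NC(=O)c2cccc(Cl)c2)c1)c1ccc(Cl)cc1` and compound 3 `O=C(Nc1cccc(NC(=O)C2CC2c2ccccc2)c1)c1cccc(Cl)c1`. In an in vitro functional assay on HEK293-A cells for antagonist activity at metabotropic glutamate receptor 5 (Rattus norvegicus), read by calcium flux (on this read-out higher numbers stand for weaker inhibition and lower numbers for stronger inhibition), compound 1 gives 2620 nM. Compound 2 reaches only the limit of this assay, > 30000 nM. Compound 3 also stands at the limit of this assay, > 30000 nM, so its true number is not known. Compound 4 `O=C(Nc1cccc(NC(=O)C2CCCCC2)c1)c1cccc(Cl)c1` differs from compound 3 by cyclohexyl in place of 2-phenylcyclopropyl on a carbonyl carbon. The measured steps that bear on this place were an at least 11-fold higher number from compound 1 to compound 2 (1.05 log units; beyond the scatter) and an at least 11-fold higher number from compound 1 to compound 3 (1.05 log units; beyond the scatter), both large and both away from 2-chlorophenyl, and the limit of > 30000 nM in this assay, at which 2 of the 3 values shown sit, is where two of the three values sit. Compound 4 is therefore expected to stay near that limit, a step of a number no higher from compound 3 to compound 4 (the limit leaves the size open). Compound 4 is estimated at 30000 nM, between 10000 nM and 100000 nM.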

Compound 4, half-maximal inhibitory concentration: > 30000 nM
Compound 4 ended at the assay's limit; the forecaster's own chance of this, stated with the estimate: 70%; the middle value sits exactly at the limit.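

With no aromatic ring in the group at all, cyclohexyl in place of 2-chlorophenyl on a carbonyl carbon still brings an at least 11-fold higher number from compound 1 to compound 4 (1.05 log units; beyond the scatter) in this assay. A third, differently shaped replacement has now failed here, leaving compound 1 as the only compound shown with a readable number: the limit of > 30000 nM in this assay, at which 3 of the 4 values shown sit. The steps among compound 2, compound 3 and compound 4 cannot be read, as all three values are limits. Still open, on these data alone, is whether a 2-fluorophenyl or 2-methylphenyl group would keep a readable number, and whether a small acetyl-type methyl group or an amine-bearing chain could do so.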